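Compound 4 and a Half-Life Held at a Limit

A few compounds are considered here, and "the series" means these few. Any claim that something is new, unique, unknown or untested is made for them only; others in the source may bear on it.

Three compounds sharing one core have been followed in an ADME assay on microsomes from liver (Mus musculus) for metabolic stability, read by LC-MS, using NADPH, with stated times of 15 min and 60 min, tested at 4.6 uM; on this read-out higher numbers stand for a longer-lived compound and lower numbers for a shorter-lived compound. Compound 3 `CN1CCN(c2ccc3c(c2)oc(=O)n3C(=O)NCCCCc2ccccc2)CC1` stands at a limit and not at a number, < 0.0834 h. Compound 1 `CN1CCN(c2ccc3c(c2)oc(=O)n3C(=O)NCCCCc2ccccc2)C(=O)C1` also gives only a limit, < 0.0834 h. Compound 2 `CC(C)CN1CCC(c2ccc3c(c2)oc(=O)n3C(=O)NCCCCc2ccccc2)CC1` gives a number, 1 h. The low end of the series is therefore crowded, with the limit of < 0.0834 h in this assay, at which 2 of the 3 values shown sit.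

Compound 4 `CN1CCN(c2ccc3c(c2)oc(=O)n3C(=O)NCCCCc2ccccc2)CC1=O` differs from compound 3 in one place: 4-methyl-3-oxopiperazin-1-yl in place of 4-methylpiperazin-1-yl on an aromatic carbon. In words, 4-methyl-3-oxopiperazin-1-yl stands in place of 4-methylpiperazin-1-yl on an aromatic carbon. The closest measured comparison exchanges 4-methyl-2-oxopiperazin-1-yl for 4-methylpiperazin-1-yl, and it is a step that the two limits leave unreadable from compound 1 to compound 3. The two large steps, an at least 11-fold higher number from compound 1 to compound 2 (1.07 log units; beyond the scatter) and an at least 11-fold lower number from compound 2 to compound 3 (1.07 log units; beyond the scatter), both turn on 1-isobutylpiperidin-4-yl, a group that compound 4 does not carry. They therefore say little about this change.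

No step beyond the scatter is expected in this assay, in either direction, and a report of only a limit is the likelier outcome. The expected change is a step that the limit leaves unreadable from compound 3 to compound 4. Compound 4 is estimated at 0.08 h, with an expected range from 0.04 h to 0.2 h.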

Compound 4, half-life: 0.5 h
For compound 4 the middle estimate is 6.3-fold (0.80 log units) below the measured one; measured number outside the range, above it.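

Among these compounds, on this aromatic carbon, 4-methyl-3-oxopiperazin-1-yl in place of 4-methylpiperazin-1-yl gives, in this assay, the first readable step among the piperazine groups, an at least 5.9-fold higher number from compound 3 to compound 4 (0.77 log units; beyond the scatter). The other oxopiperazine does not share this result, with an at least 5.9-fold higher number from compound 1 to compound 4 (0.77 log units; beyond the scatter), so on the compounds shown the place of the carbonyl in the ring separates the two groups. The comparison with the piperidine group gives a 2.0-fold lower number from compound 2 to compound 4 (0.30 log units; within the scatter), so 1-isobutylpiperidin-4-yl is no longer the only group on this carbon to give a number and not a limit, and the low end of the series is left to two compounds: the limit of < 0.0834 h in this assay, at which 2 of the 4 values shown sit.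

As far as these compounds go, compound 1 and compound 3 are known only through limits, so the steps that start from them give a smallest size and their true size remains open. Also open, from the compounds shown here alone, is whether the result extends to other groups on this carbon, such as a morpholine or a 3-oxopiperazine without its methyl group.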